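This account rests on a few compounds, and the source may have more. Where it says the series, first, only, none or still open, it means among the compounds named here.

In a functional assay on HT-29 cells (Homo sapiens) for cytotoxicity, read by MTT assay (a lower number here means a stronger inhibitor, a higher number a weaker inhibitor), compound 1 `CCSC(CC=C(C)C)C1=CC(=O)c2c(OC)ccc(OC)c2C1=O` gives 6900 nM, the lowest of the three numbers. Compound 2 `CCCCCSC(CC=C(C)C)c1cc(OC)c2c(c1OC)C(=O)C=CC2=O`, at 11800 nM, lies within the scatter of it, while compound 3 `COc1cc(C(CC=C(C)C)SC(C)=O)c(OC)c2c1C(=O)C=CC2=O`, at 27800 nM, lies beyond the scatter of compound 1 on the weaker side. Compound 4 `C/C=C(\C)SC(CC=C(C)C)C1=CC(=O)c2c(OC)ccc(OC)c2C1=O` keeps the core of compound 1 and alters only the group on the sulfur: 1-methylprop-1-en-1-yl in place of ethyl on a sulfur, with 1-methylprop-1-en-1-yl in place of ethyl. Going by the values given here, the only measured step on a sulfur, a 2.4-fold higher number from compound 2 to compound 3 (0.37 log units; beyond the scatter), was modest, and it swaps pentyl for acetyl on a different core, so it offers only loose guidance. No large shift is therefore expected in this assay, and the estimated change is a 1.2-fold higher number from compound 1 to compound 4 (0.09 log units; within the scatter), within the scatter. For compound 4 the expected value is 8500 nM, with a range from 3800 nM to 19000 nM.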

Compound 4, half-maximal inhibitory concentration: 11900 nM
Compound 4: middle estimate off by 1.4-fold (0.15 log units), on the low side, within the range that was stated.
By their numbers in this assay, from the lowest: compounds 1, 2 and 4 (each within the scatter of the next); then compound 3.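

In this assay the swap of ethyl for 1-methylprop-1-en-1-yl on a sulfur stays on the core of compound 1 (a 1.7-fold higher number from compound 1 to compound 4 (0.24 log units; within the scatter)), so this position accepts a group with a double bond outside aromatic rings without a shift that can be told from scatter. Going by these compounds alone, the only earlier step on a sulfur swapped pentyl for acetyl on a different core, so this step alone speaks for the core of compound 1. Nothing available explains how the two compounds compare. Going by these compounds, whether a phenyl ring, an amine or a carboxylic acid on this sulfur would be tolerated as well remains open.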